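A few compounds are considered here, and "the series" means these few. Any claim that something is new, unique, unknown or untested is made for them only; others in the source may bear on it.

Of the compounds shown here, two built on one shared core have been measured in a functional assay on the whole organism for inhibition, with Rattus norvegicus as the target, read by paw edema, with stated times of 30 min and 3 h, at a dose of 0.28 mmol/kg by the oral route; a lower number here means less inhibition, a higher number more inhibition at the dose given (going by the name of the read-out). Compound 1 `CCNC(=O)c1nc(-c2cc(OC)c(OC)c(OC)c2)n(-c2ccc(OC)cc2)n1` carries an ethyl group on its amide-type nitrogen, and in this assay compound 1 gives 69%. Within the data shown here, compound 2 `COc1ccc(-n2nc(C(=O)Nc3ccccc3OC)nc2-c2cc(OC)c(OC)c(OC)c2)cc1` carries a 2-methoxyphenyl group on that nitrogen instead, and compound 2 gives 30%, which places compound 2 lowest of the two numbers known so far. Among the measured compounds shown here, the single measured step, a number 39 percentage points lower from compound 1 to compound 2 (beyond the scatter), shows that the group on this nitrogen can move the read-out strongly. Compound 3 `COc1ccc(-n2nc(C(=O)Nc3cccc(F)c3)nc2-c2cc(OC)c(OC)c(OC)c2)cc1` has not been measured; it differs from compound 2 in one place: 3-fluorophenyl in place of 2-methoxyphenyl on an amide-type nitrogen. For the measured compounds named here, no measured step exchanges one aromatic ring for another at this position, so the one known step bears on the question only by showing that the position matters, not in which direction a second aromatic ring would move the number. A moderate shift either way is plausible, so compound 3 is expected to give roughly 40%, between 20% and 62%. This corresponds to an expected step of a number 10 percentage points higher from compound 2 to compound 3 (within the scatter).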

Compound 3, a percentage reported as inhibition, in the whole organism at one dose (the size of the read-out at that dose, not a potency): 72%
For compound 3 the middle estimate is 32 percentage points below the measured one, and the stated range ends below it.
By their numbers in this assay, from the lowest: compound 2; then compounds 1 and 3 (each within the scatter of the next).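

In this assay, putting 3-fluorophenyl on the amide-type nitrogen gives a number 42 percentage points higher from compound 2 to compound 3 (beyond the scatter), so the low number of compound 2 does not come with every aromatic ring at this position. Set against the ethyl group, the same exchange gives a number 3 percentage points higher from compound 1 to compound 3 (within the scatter), which means that an ethyl group and a 3-fluorophenyl group cannot be told apart in this read-out, and that among these three compounds only the 2-methoxyphenyl group stands out. No measurement is available that explains this difference between the groups.

The step from compound 2 to compound 3 changes both the substituent on the ring, methoxy to fluoro, and its numbered place, so the compounds shown cannot say which of the two matters; 2-fluorophenyl and 3-methoxyphenyl, together with plain phenyl, would separate these effects. On these data alone, it also remains open how a longer chain such as butyl, or an amine-bearing chain, would behave on this nitrogen, and since each number comes from a single dose, none of them says how potent a compound is.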